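The source may hold more compounds than are shown below. What is called first, only, known or untested is meant among the compounds shown, and "the series" means these compounds.

Compound 1, `CCC1(CC)CC(C)(C)Oc2ccc(NC(=O)Nc3ccc(C(F)(F)F)cc3)cc21`, gives 93.3% in a functional assay on A2780 cells (Homo sapiens) for inhibition, with a stated time of 72 h, tested at 10 uM; on this read-out higher numbers stand for more inhibition of growth at the one concentration tested and lower numbers for less inhibition of growth.
Compound 2, `CCC1(CC)CC(CC)(CC)c2cc(NC(=O)Nc3ccc(OC(F)(F)F)cc3)ccc2O1`, gives 67% in this assay.

Of these two, compound 2 stands lower, and the gap between it and compound 1 is wider than the usual scatter of such measurements. Compound 3, `CCC1(CC)CC(CC)(CC)c2cc(NC(=O)Nc3ccc([N+](=O)[O-])cc3)ccc2O1`, has not yet been measured. It differs from compound 2 in one place: nitro in place of trifluoromethoxy on an aromatic carbon. Going by the values given here, no pair of measured compounds shows this same exchange, so nothing here tells how large such a step tends to be or in which direction it goes. With only that to rest on, the expectation for compound 3 is a value near that of compound 2, with a step from compound 2 to compound 3 of a number 7 percentage points lower from compound 2 to compound 3 (within the scatter) that may well fall within the scatter. Compound 3 is therefore estimated at 60% in this assay, within a range of 35% to 85%.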

Compound 3, percent growth inhibition at one concentration: 91.4%
The estimate for compound 3 lay 31.4 percentage points below the measured number, and the stated range ends below it.
By their numbers in this assay, from the lowest: compound 2; then compounds 3 and 1 (each within the scatter of the next).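

The exchange of 4-(trifluoromethoxy)phenyl for 4-nitrophenyl gives a number 24.4 percentage points higher from compound 2 to compound 3 (beyond the scatter) in this assay. This is the first change at a single place among these compounds, and it shows that the group on this aromatic carbon can shift growth inhibition at the one concentration tested by more than ordinary scatter. Nothing available explains why the step goes upward, and no separate measurement bears on it.

As far as these compounds go, this single pair cannot show whether other groups at this position would behave in the same way, so how an amine, a nitrile or a carboxylic acid would compare remains open. Also open, from the compounds shown here alone, is whether the same exchange on the core of compound 1 would give a step of similar size and direction.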